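The source may report more compounds than this note shows. Statements on the series, on what has been measured and on what is new or still open speak of the compounds shown alone.

Compound 2 `Oc1ccc(-c2cc(-c3cccs3)cc(-c3ccccc3O)n2)cc1` has been run in a functional assay on T47D cells (Homo sapiens) for cytotoxicity, read by CCK-8 assay (on this read-out higher numbers stand for weaker inhibition and lower numbers for stronger inhibition), and gives only a limit there, > 50000 nM. Compound 1 `Oc1ccccc1-c1cc(-c2cccs2)cc(-c2ccccc2O)n1` likewise gives a limit, > 50000 nM. The step that the two limits leave unreadable from compound 1 to compound 2; both its ends sit at the limit of > 50000 nM in this assay, at which 2 of the 3 values shown sit. Compound 3 `Oc1cccc(-c2cc(-c3cccs3)cc(-c3cccc(O)c3)n2)c1`, carrying two 3-hydroxyphenyl groups, gives a measured number in this assay, 770 nM. Compound 4 `Oc1ccc(-c2cc(-c3cccs3)cc(-c3ccc(O)cc3)n2)cc1` differs from compound 2 by 4-hydroxyphenyl in place of 2-hydroxyphenyl on an aromatic carbon. Going by the values given here, the only measured step of this kind is the unreadable one, so no size can be taken from it. The estimate for compound 4 is 15000 nM, within 1500 nM to 50000 nM. That expectation corresponds to a step of an at least 3.3-fold lower number from compound 2 to compound 4 (0.52 log units; beyond the scatter), with a real chance that compound 4 again returns only a limit.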

Compound 4, half-maximal inhibitory concentration: 11700 nM
Compound 4: the middle estimate sits 1.3-fold (0.11 log units) above what was measured; the measured number falls inside the stated range.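

In this assay, going by these compounds alone, the swap of 2-hydroxyphenyl for 4-hydroxyphenyl, next to the ring nitrogen, gives an at least 4.2-fold lower number from compound 2 to compound 4 (0.63 log units; beyond the scatter) and is the first readable size for this change, whereas the same change from compound 1 to compound 2 cannot be read. At this position, meta to a 4-hydroxyphenyl group, the change thus separates a limit from a measured number. The size is only a lower bound because compound 2 gives a limit: the limit of > 50000 nM in this assay, at which 2 of the 4 values shown sit.

On these data alone, the true size of the step stays open. So does whether an amine in place of the hydroxyl of the 4-hydroxyphenyl group would keep the activity of compound 4.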